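A few compounds are considered here, and "the series" means these few. Any claim that something is new, unique, unknown or untested is made for them only; others in the source may bear on it.

Compound 1 `Cc1c(C(=O)OC(C)C(C)(C)C)c[nH]c1C(=O)Oc1cccnc1` is the strongest of the three measured compounds in an assay on CHO cells for inhibition of metabotropic glutamate receptor 1 (Rattus norvegicus); on this read-out lower numbers stand for stronger inhibition and higher numbers for weaker inhibition: compound 1 gives 720 nM, and its steps to both other compounds lie beyond the scatter. Compound 2 `CCCOC(=O)c1[nH]c(COC(C)=O)c(C(=O)OC(C)(C)C)c1C` gives 2700 nM in this assay, and compound 3 `CCCOC(=O)c1[nH]c(C=O)c(C(=O)OC(C)(C)C)c1C` gives 2000 nM. For the measured compounds named here, the only measured step between neighbours, a 1.4-fold lower number from compound 2 to compound 3 (0.13 log units; within the scatter), stays within the scatter and concerns a different place on the shared core, so it does not bear on the change that leads from compound 1 to compound 4 `Cc1c(C(=O)OC(C)C(C)(C)C)c[nH]c1C(=O)OC(C)(C)C`, where the difference is tert-butyl in place of pyridin-3-yl on an oxygen next to a carbonyl group. Going by the values given here, no measured pair shows a pyridin-3-yl group exchanged for a tert-butyl group on an oxygen next to a carbonyl group, so the expectation rests on the general observation that the one step recorded here is small. Compound 4 is therefore expected to stay in the neighbourhood of compound 1, with an estimated step of a 1.7-fold higher number from compound 1 to compound 4 (0.22 log units; within the scatter) in this assay, most likely a mild weakening that may or may not exceed the scatter. The estimate for compound 4 in this assay is 1200 nM, within a range from 400 nM to 4000 nM.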

Compound 4, half-maximal inhibitory concentration: 17 nM
Beside the measured number, compound 4's estimate is 71-fold (1.85 log units) above it; the measured number lies below the stated range.
By their numbers in this assay, from the lowest: compound 4; then compound 1; then compounds 3 and 2 (each within the scatter of the next).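

For the compounds shown here, the exchange on the oxygen next to a carbonyl group produces a large change in this assay, a 42-fold lower number from compound 1 to compound 4 (1.63 log units; beyond the scatter), whereas the only earlier step, a 1.4-fold lower number from compound 2 to compound 3 (0.13 log units; within the scatter), lay within the scatter and concerned another place on the shared core. This position therefore responds strongly to the group it carries, and compound 4 shows that a six-membered aromatic ring on this oxygen is not needed for a low number here, since the tert-butyl group, with no ring, gives a far lower number than pyridin-3-yl does in compound 1. Nothing available explains why this exchange has so large an effect on the number.

Because pyridin-3-yl and tert-butyl differ at once in ring, ring nitrogen and heavy-atom count, the compounds shown do not separate these differences: a phenyl group on the same oxygen would isolate the ring nitrogen, while an isopropyl or cyclohexyl group would test how much of the tert-butyl group is required. From the compounds shown here alone, how an amide nitrogen in place of this oxygen would read also remains open.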